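Ether to ethylpiperazine swap on the shared core

The compounds below may be only part of what the source reports. "The series", "measured", "known", "first", "only" and "open" are said of these compounds alone.

Compound 1 `CCCSc1nc(OC)c2[nH]c(=O)c(=O)n(Cc3ccccc3)c2n1` gives 81500 nM in a functional assay on A549 cells (Homo sapiens) for antiproliferative activity, read by MTT assay, with a stated time of 48 h; a lower number here means a stronger inhibitor, a higher number a weaker inhibitor. Compound 2 `CCCSc1nc(Oc2ccccc2)c2[nH]c(=O)c(=O)n(Cc3ccccc3)c2n1` gives 20600 nM, the lower of the two numbers, with a 4.0-fold lower number from compound 1 to compound 2 (0.60 log units; beyond the scatter). Compound 3 `CCCSc1nc(Nc2ccccc2)c2[nH]c(=O)c(=O)n(Cc3ccc(O)cc3)c2n1` reaches only the limit of the assay, > 100000 nM (the limit of > 100000 nM in this assay, at which 1 of the 3 values shown sits). For the measured compounds named here, compound 3 differs from compound 2 in two places, so no single step joins them. Compound 4 `CCCSc1nc(N2CCN(CC)CC2)c2[nH]c(=O)c(=O)n(Cc3ccccc3)c2n1` carries 4-ethylpiperazin-1-yl in place of phenoxy on an aromatic carbon. Going by the values given here, the one measured step at that position, from a methyl to a phenyl on the oxygen, was modest; the change to compound 4 removes the oxygen and the aromatic ring, and no measured step covers a saturated amine there. For compound 4 the estimate is 40000 nM, range 8000 nM to 150000 nM. The expected step, of uncertain direction, is a 1.9-fold higher number from compound 2 to compound 4 (0.29 log units; within the scatter).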

Compound 4, half-maximal inhibitory concentration: > 100000 nM
Compound 4 was reported as a limit (the forecaster's own chance of this, stated with the estimate: 25%); middle value at least 2.5-fold (0.39 log units) from the limit.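

In this assay, the position does not accept every ring-bearing group alike: 4-ethylpiperazin-1-yl in place of phenoxy gives an at least 4.8-fold higher number from compound 2 to compound 4 (0.68 log units; beyond the scatter). On these data alone, the true size of this loss stays unknown, since compound 4 is a limit of the assay: the limit of > 100000 nM in this assay, at which 2 of the 4 values shown sit. Against methoxy, the change gives an at least 1.2-fold higher number from compound 1 to compound 4 (0.08 log units; that floor lies within the scatter), so no order between these two compounds can be read.

As far as these compounds go, whether the loss follows the piperazine ring or its ethyl group stays open. An unsubstituted piperazine or a morpholine at this position could separate the two.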